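Removing One Trifluoromethyl Group From a Diaryl Urea

A few compounds are considered here, and "the series" means these few. Any claim that something is new, unique, unknown or untested is made for them only; others in the source may bear on it.

Measured so far:
Compound 1, `O=C(Nc1cccc(-n2cc(-c3ccncc3)c(-c3cc(O)cc(Cl)c3)n2)c1)Nc1ccc(Cl)c(C(F)(F)F)c1`, gives 97%
Compound 2, `O=C(Nc1cccc(-n2cc(-c3ccncc3)c(-c3cc(O)cc(Cl)c3)n2)c1)Nc1ccc(Cl)c(Cl)c1`, gives 108%
Compound 3, `COc1cc(Cl)cc(-c2nn(-c3cccc(NC(=O)Nc4cc(C(F)(F)F)cc(C(F)(F)F)c4)c3)cc2-c2ccncc2)c1`, gives 103%

These three numbers come from a functional assay on SK-MEL-28 cells (Homo sapiens) for inhibition, read by sulforhodamine B assay, with a stated time of 48 h, tested at 0.01 uM (on this read-out higher numbers stand for a weaker effect at the one concentration tested and lower numbers for a stronger effect), and all sit close together. Compound 3 stands second highest of the three, but its gap to compound 2 and its gap to compound 1 both lie within the scatter, so no ranking among them can be read.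

Compound 4, `COc1cc(Cl)cc(-c2nn(-c3cccc(NC(=O)Nc4cccc(C(F)(F)F)c4)c3)cc2-c2ccncc2)c1`, differs from compound 3 in one place: hydrogen in place of trifluoromethyl on an aromatic carbon. Among the measured compounds shown here, no measured step removes a trifluoromethyl group outright. The nearest comparison is a number 11 percentage points higher from compound 1 to compound 2 (beyond the scatter), a modest shift that came from swapping a trifluoromethyl group for chloro. Given that compound 3 already gives 103%, a value near the top of the scale, the change to compound 4 is expected to produce little or no step beyond the scatter in this assay, with a number 1 percentage points lower from compound 3 to compound 4 (within the scatter) as the expected step. The estimate for compound 4 is therefore 102%, with a range from 90% to 114%.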

Compound 4, a percentage reported as activity, at one concentration (the size of the read-out at that concentration, not a potency): 99%
Compound 4: the middle estimate sits 3 percentage points above what was measured, within the range that was stated.
By their numbers in this assay, from the lowest: compounds 1, 4, 3 and 2 (each within the scatter of the next, the first and the last beyond it).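

In this assay, hydrogen in place of trifluoromethyl gives a number 4 percentage points lower from compound 3 to compound 4 (within the scatter). Compound 3 carries two trifluoromethyl groups on its six-membered aromatic ring of carbon only, and this step shows that, at this one low concentration, the read-out does not separate the compound with both groups from the compound with one. The earlier step, a number 11 percentage points higher from compound 1 to compound 2 (beyond the scatter), exchanged trifluoromethyl for chloro in another pair, so it could not show what outright loss of the group does; nothing measured here explains the result.

A single concentration cannot show whether compound 3 and compound 4 would separate at higher doses. On these data alone, it also remains open whether an amine or a carboxylic acid on this carbon would shift the number beyond the scatter.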